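A few compounds are considered here, and "the series" means these few. Any claim that something is new, unique, unknown or untested is made for them only; others in the source may bear on it.

Three compounds share one core and differ in the group attached to it. In an assay on HEK293 cells for inhibition of Steryl-sulfatase (Homo sapiens), tested at 0.1 uM (a lower number here means a weaker effect, a higher number a stronger effect of the compound at the concentration tested), compound 1 `CCN(Cc1ccccn1)c1ccc(C(=O)N2CCc3ccc(OS(N)(=O)=O)cc3C2)cc1` gives 42.5%, the highest number among the three. Compound 3 `CN(CCCN1CCCCC1)c1cccc(C(=O)N2CCc3ccc(OS(N)(=O)=O)cc3C2)c1` gives 24.1% in this assay, and compound 2 `NS(=O)(=O)Oc1ccc2c(c1)CN(C(=O)c1cccc(N3CCCCC3)c1)CC2` gives 1%. The gap from compound 1 to compound 3 and the larger gap from compound 1 to compound 2 both lie beyond the scatter. Going by the values given here, the one measured step between compounds that differ in a single place is a number 23.1 percentage points higher from compound 2 to compound 3 (beyond the scatter), which concerns the group on the aromatic carbon, a different place from the change considered here.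

Compound 4 `CCN(Cc1cccc(Br)c1)c1ccc(C(=O)N2CCc3ccc(OS(N)(=O)=O)cc3C2)cc1` is not yet measured. It differs from compound 1 in one place: 3-bromophenyl in place of pyridin-2-yl on a saturated chain carbon bound to a nitrogen on an aromatic ring. Among the compounds with values here, no measured step touches this position, so there is no direct guide to its size or direction. Within the data shown here, the only known step shows that changing the group on that side of the molecule can shift the number by a modest amount. Compound 4 is therefore estimated at 35%, with a range from 15% to 58%. The expected step is a number 7.5 percentage points lower from compound 1 to compound 4 (within the scatter), small and possibly within the scatter.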

Compound 4, a percentage reported as inhibition, at one concentration (the size of the read-out at that concentration, not a potency): 80.2%
Compound 4: middle estimate off by 45.2 percentage points, on the low side; the measured number lies above the stated range.
By their numbers in this assay, from the lowest: compound 2; then compound 3; then compound 1; then compound 4.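

In this assay the change from pyridin-2-yl to 3-bromophenyl gives a number 37.7 percentage points higher from compound 1 to compound 4 (beyond the scatter) and so shows that this place, on a saturated chain carbon bound to a nitrogen on an aromatic ring, strongly affects the read-out. Going by these compounds alone, the earlier compounds could not show this, as their only measured step concerned a different group, and a swap between two single aromatic rings of almost the same size, 6 and 7 heavy atoms, might have seemed a minor edit. Nothing available explains why the number moves this far.

The swap removes the ring nitrogen and adds a bromine in one move, so the compounds shown cannot tell which of the two carries the step; plain phenyl, which has neither, and 3-chlorophenyl, which keeps a halogen in the same named position, would help to separate them. Also open, going by these compounds, is whether the ethyl of the (3-bromobenzyl)(ethyl)amino group can give way to a longer chain such as propyl without losing this higher number.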